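Methyl in Place of Hydrogen on an Alkynyl Lactam

The source may hold more compounds than are shown below. What is called first, only, known or untested is meant among the compounds shown, and "the series" means these compounds.

Compound 1 `O=C1NCCc2nc(C#Cc3ccccc3)sc21` is a small lactam joined through an alkyne to a benzene ring. In an assay on HEK293 cells for negative allosteric modulation of metabotropic glutamate receptor 5 (Homo sapiens), read by FLIPR, with a stated time of 1 h (on this read-out higher numbers stand for weaker inhibition and lower numbers for stronger inhibition), compound 1 gives > 10000 nM, which is a limit of the assay and not a number. Compound 2 `O=C1NCCc2nc(C#Cc3ccccc3F)sc21` carries a fluoro in place of hydrogen on an aromatic carbon; in this assay compound 2 gives > 10000 nM, again a limit. Compound 3 `COc1ccccc1C#Cc1nc2c(s1)C(=O)NCC2` carries a methoxy in place of hydrogen on an aromatic carbon; in this assay compound 3 gives > 10000 nM, also a limit. The steps a step that the two limits leave unreadable from compound 1 to compound 2 and a step that the two limits leave unreadable from compound 1 to compound 3 therefore cannot be sized, because of the limit of > 10000 nM in this assay, at which 3 of the 3 values shown sit. Compound 4 `Cc1cccc(C#Cc2nc3c(s2)C(=O)NCC3)c1` differs from compound 1 by methyl in place of hydrogen on an aromatic carbon. With every comparable change leaving the value at the limit, compound 4 is expected to stay near it, with an estimated step that the limit leaves unreadable from compound 1 to compound 4. The estimated value of compound 4 is 12000 nM, ranging from 2000 nM to 50000 nM.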

Compound 4, half-maximal inhibitory concentration: > 10000 nM
Compound 4 gave a limit, no number; the forecaster's own chance of this, stated with the estimate: 75%; the middle value is on the limit's open side.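

Compound 4, like compound 1, sits at a limit and not at a number, so no step between them can be read: the limit of > 10000 nM in this assay, at which 4 of the 4 values shown sit.

The compounds shown leave open how strongly any of them inhibits, and whether fluoro, methoxy or methyl changes that at all.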